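This account rests on a few compounds, and the source may have more. Where it says the series, first, only, none or still open, it means among the compounds named here.

Compound 1 `O=C(CSc1nc(Cc2c(Cl)cccc2Cl)cc(=O)[nH]1)c1ccc(F)cc1` and compound 2 `COc1ccc(C(=O)CSc2nc(Cc3c(Cl)cccc3Cl)cc(=O)[nH]2)cc1` share one core and differ by methoxy in place of fluoro on an aromatic carbon. In an ADME assay on MT4 cells (Homo sapiens) for cytotoxicity, read by MTT assay (on this read-out higher numbers stand for lower toxicity in this test and lower numbers for higher toxicity in this test), compound 1 gives only a limit, > 59000 nM. In this assay compound 2 likewise gives only a limit, > 11000 nM. The step that the two limits leave unreadable from compound 1 to compound 2 is therefore not readable in size. Compound 3 `CC(C)c1c(Cc2c(F)cccc2Cl)nc(SCC(=O)c2ccc(F)cc2)[nH]c1=O` carries a different core; the difference between the two cores is not broken down here. In this assay compound 3 gives only a limit, > 56000 nM. Compound 4 `COc1ccc(C(=O)CSc2nc(Cc3c(F)cccc3Cl)c(C(C)C)c(=O)[nH]2)cc1` is not yet measured and differs from compound 3 by methoxy in place of fluoro on an aromatic carbon, the same change as from compound 1 to compound 2. Compound 4 is expected to sit at a limit again, with the expected step of an at least 1.1-fold lower number from compound 3 to compound 4 (0.04 log units; that floor lies within the scatter). That expectation rests on compound 2, whose value > 11000 nM is a limit. Compound 4 is estimated at 50000 nM, between 15000 nM and 120000 nM.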

Compound 4, half-maximal cytotoxic concentration: > 11000 nM
Compound 4: only a limit was reported (the forecaster's own chance of this, stated with the estimate: 85%); the middle value is on the limit's open side.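

Compound 3 and compound 4 both give only limits in this assay, so the step between them cannot be read. The compounds shown leave open whether methoxy in place of fluoro shifts the half-maximal cytotoxic concentration at all.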